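This account rests on a few compounds, and the source may have more. Where it says the series, first, only, none or still open, it means among the compounds named here.

Working notes on the series.

Compound 1 `CCCCCCCCCCCC(=O)OC[C@H](CSC[C@@H](N)C(=O)NCCCCCCO)OC(=O)CCCCCCCCCCC` and compound 2 `CCCCCCCCCCCC(=O)OC[C@H](CSC[C@@H](N)C(=O)NC(C)CCc1ccccc1)OC(=O)CCCCCCCCCCC` share the same core and differ only at the amide-type nitrogen. In an assay on HEK293 cells for agonist activity at Toll-like receptor 2 (Homo sapiens) (a higher number here means that more compound is needed for the effect, a lower number that less compound is needed), compound 1 gives 33 nM, and compound 2 gives 160 nM. Going by the values given here, the one step measured so far, a 4.8-fold higher number from compound 1 to compound 2 (0.69 log units; beyond the scatter), follows replacement of 6-hydroxyhexyl by 1-methyl-3-phenylpropyl. Among the compounds with values here, compound 2 thus stands at the highest number of the two measured, with compound 1 the only neighbour.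

Compound 3 `CCCCCCCCCCCC(=O)OC[C@H](CSC[C@@H](N)C(=O)NCCCCCCCCCC(=O)O)OC(=O)CCCCCCCCCCC` carries the change (9-carboxynonyl in place of 1-methyl-3-phenylpropyl on an amide-type nitrogen). The entering group has no ring and, as counted, one hydrogen-bond donor and one hydrogen-bond acceptor, which places it closer to the 6-hydroxyhexyl of compound 1 than to the group it replaces. Within the data shown here, the only bearing step is a 4.8-fold higher number from compound 1 to compound 2 (0.69 log units; beyond the scatter), which ran toward a higher number when the ring-bearing group entered; the reverse direction is therefore the expectation here, of modest size. For compound 3 the expected step is a 3.2-fold lower number from compound 2 to compound 3 (0.51 log units; beyond the scatter), because compound 1 with a chain at this position gave 33 nM. Compound 3 is estimated at 50 nM, with a range of 15 nM to 200 nM, and the measured value will show whether a chain ending in a carboxyl behaves like one ending in a hydroxyl.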

Compound 3, half-maximal effective concentration: 4400 nM
Beside the measured number, compound 3's estimate is 88-fold (1.94 log units) below it; measured number outside the range, above it.
By their numbers in this assay, from the lowest: compound 1; then compound 2; then compound 3.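

In this assay, a chain without a ring does not by itself give a low number at the amide-type nitrogen: 9-carboxynonyl in place of the ring-bearing 1-methyl-3-phenylpropyl gives a 28-fold higher number from compound 2 to compound 3 (1.44 log units; beyond the scatter). The comparison of the two chains is sharper still, with 3-carboxypropyl in place of hydroxy on the saturated chain carbon giving a 130-fold higher number from compound 1 to compound 3 (2.12 log units; beyond the scatter), the largest step among these compounds, so the make-up of the chain matters here more than the earlier step, with its ring-bearing group, could show. Nothing available bears on the cause of this rise.

Compound 1 and compound 3 differ in both chain length and chain end, so the compounds shown do not separate the two: a carboxylic acid on a shorter chain, or a hydroxyl at the end of a longer chain, would tell them apart. Also open, on these data alone, is how a primary amine at the chain end, or a plain alkyl chain with no terminal group, would stand against the hydroxyl and the carboxyl.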